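Turning the double bond of compound 2 from Z to E

The source may hold more compounds than are shown below. What is called first, only, known or untested is meant among the compounds shown, and "the series" means these compounds.

compound 1 `COc1cc(/C=C\c2ccnc3ccccc23)cc(OC)c1OC` gives 7940 nM
compound 2 `COc1cc(/C=C\c2ccc3nccnc3c2)cc(OC)c1OC` gives 7940 nM

In a functional assay on SK-MEL-28 cells (Homo sapiens) for cytotoxicity (a lower number here means a stronger inhibitor, a higher number a weaker inhibitor), compound 1 and compound 2 stand level at the digits shown, with compound 2 at 7940 nM and no measured compound apart from compound 1 to set it against. Compound 3 `COc1cc(/C=C/c2ccc3nccnc3c2)cc(OC)c1OC` is the next to be read. The change is one of configuration alone: the two compounds have the same atoms and bonds and differ only in configuration as drawn: 1 of 1 stereo elements differ; a double bond is drawn Z in compound 2 and E in compound 3. Among the measured compounds shown here, no pair of measured compounds shows what such a change does, so any expectation here is a cautious one. The expected step of a 1.4-fold higher number from compound 2 to compound 3 (0.14 log units; within the scatter) is small, towards a weaker number, and it may well stay within the scatter. In this assay compound 3 is expected at 11000 nM with an estimated range from 4000 nM to 32000 nM until a measurement settles it.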

Compound 3, half-maximal inhibitory concentration: > 15800 nM
Compound 3: only a limit was reported (the forecaster's own chance of this, stated with the estimate: 35%); at least 1.4-fold (0.15 log units) between middle value and limit.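

Compound 3 gives > 15800 nM in this assay, and this value is a limit of the assay, not a number. Among the compounds shown here, this is the first reading of a change in the configuration of the double bond, and it comes as an at least 1.9-fold higher number from compound 2 to compound 3 (0.29 log units; that floor lies within the scatter), so the true size of the step is unknown and the pair cannot be told apart beyond the scatter. The reading isolates the configuration and nothing else: the fact that compounds 2 and 3 differ only in the configuration as drawn

The compounds shown leave open how far the step really reaches, and whether the same change would read alike on the core of compound 1. They also leave open what an amine or a carboxylic acid on the shared core would do to the level of compound 2 at 7940 nM.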